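A Fluoromethoxy Variant of Compound 2

A few compounds are considered here, and "the series" means these few. Any claim that something is new, unique, unknown or untested is made for them only; others in the source may bear on it.

compound 1 `COC[C@@H](C1CC1)n1cc(Cl)nc(Nc2cc(C)c(OCCF)cc2C)c1=O`: 2.4 nM
compound 2 `COCC(COC)n1cc(Cl)nc(Nc2c(Cl)cc(OC)cc2Cl)c1=O`: 5 nM

In an assay on frontal cortex for displacement of a labelled ligand from corticotropin-releasing factor receptor 1 (Rattus norvegicus), with a stated time of 2 h (a lower number here means a stronger inhibitor, a higher number a weaker inhibitor), compound 1 gives 2.4 nM, while compound 2 gives 5 nM. Compound 2 thus holds the higher of the two numbers, and its gap to compound 1 lies beyond the usual scatter. Compound 3 `COCC(COC)n1cc(Cl)nc(Nc2c(Cl)cc(OCF)cc2Cl)c1=O` differs from compound 2 by fluoro in place of hydrogen on a saturated chain carbon bound to an oxygen on an aromatic ring. Among the compounds with values here, no measured pair shows this single change, so its size is unknown here. So small a change is expected to move the number little, and the step of no change at the digits printed from compound 2 to compound 3 (within the scatter) is estimated to stay within the scatter. Compound 3 is therefore expected near 5 nM, between 2 nM and 12 nM.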

Compound 3, half-maximal inhibitory concentration in the corticotropin-releasing factor receptor 1 assay: 5.4 nM
Compound 3: the middle estimate sits 1.1-fold (0.03 log units) below what was measured; the measured number falls inside the stated range.
By their numbers in the corticotropin-releasing factor receptor 1 assay, from the lowest: compound 1; then compounds 2 and 3 (each within the scatter of the next).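

In the corticotropin-releasing factor receptor 1 assay compound 2 gives 5 nM and compound 3 gives 5.4 nM. In the corticotropin-releasing factor receptor 1 assay, placing fluoro on a saturated chain carbon bound to an oxygen on an aromatic ring gives a 1.1-fold higher number from compound 2 to compound 3 (0.03 log units; within the scatter) and so shows that this methoxy to fluoromethoxy change is tolerated at this position. In a physicochemical assay for lipophilicity, using the shake flask method, in phosphate buffer, measured as octanol-water partition, at pH 7.4 (on this read-out lower numbers stand for lower lipophilicity and higher numbers for higher lipophilicity), compound 2 gives 3.4 and compound 3 gives 3.1. In the physicochemical assay the same change gives a number 0.30 log units lower from compound 2 to compound 3 (within the scatter) and so does not separate the two compounds on that read-out either.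

Nothing available here offers an explanation for either result. Open, going by these compounds, is how this position would respond to a larger group, such as trifluoromethoxy, or to a longer chain, such as propoxy.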